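Neopentyl in place of 1,2-dimethylpropyl on the shared core

The compounds below may be only part of what the source reports. "The series", "measured", "known", "first", "only" and "open" are said of these compounds alone.

Among the measured compounds shown here, in a functional assay for inhibition, with Rattus norvegicus as the target (on this read-out higher numbers stand for weaker inhibition and lower numbers for stronger inhibition), compound 3 `CC(C)C(C)/N=c1\c(O)c(O)\c1=N/c1ccc(C#N)cc1` gives 1900 nM as the only single number among the three compounds measured. Compound 1 `CC(/N=c1\c(O)c(O)\c1=N/c1ccc(S(C)(=O)=O)cc1)C(C)(C)C` reads > 30000 nM and that is a limit of the assay. Compound 2 `C[C@@H](/N=c1\c(O)c(O)\c1=N/c1ccc(C#N)cc1)C(C)(C)C` has the entries 370 nM; 24300 nM (2 entries) and no single number, and compound 3 sits inside their span. Compound 4 `CC(C)(C)C/N=c1\c(O)c(O)\c1=N/c1ccc(C#N)cc1` differs from compound 3 by neopentyl in place of 1,2-dimethylpropyl on a double-bonded nitrogen with neopentyl in place of 1,2-dimethylpropyl on a double-bonded nitrogen. For the measured compounds named here, no measured step between compounds differing in one place is available to size this change. In this assay the expected 1.1-fold higher number from compound 3 to compound 4 (0.02 log units; within the scatter) is estimated to stay within the scatter with neither direction favoured. For compound 4 the estimate is 2000 nM with an expected range from 400 nM to 12000 nM in this read-out.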

Compound 4, half-maximal inhibitory concentration: > 30000 nM
Compound 4: a limit, no number; the forecaster's own chance of this, stated with the estimate: 10%; middle value at least 15-fold (1.17 log units) away from the limit.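

With the same atoms joined differently, this position on the double-bonded nitrogen proves sensitive to the shape of the chain: neopentyl in place of 1,2-dimethylpropyl gives an at least 15-fold higher number from compound 3 to compound 4 (1.19 log units; beyond the scatter) in this assay. Among the compounds shown here, the earlier compounds gave no step at this position, so this is the first sizing of a change here. The reading of compound 4 is a limit, so the step has a lower bound only: the limit of > 30000 nM in this assay, at which 2 of the 4 values shown sit.

As far as these compounds go, whether an isopropyl or cyclopentyl group at this place would keep the inhibition of compound 3 remains open. How firmly the step can be sized also remains open, because entries for a single compound spread widely here: the several entries of compound 2 in this assay, 370 nM; 24300 nM (2 entries)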